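Cyclobutyl carboxamide variant of the aminonicotinonitrile series

The source may report more compounds than this note shows. Statements on the series, on what has been measured and on what is new or still open speak of the compounds shown alone.

Measured so far in an assay on isolated protein for inhibition of protein kinase C delta type (Homo sapiens), read by TR-FRET, with a stated time of 2 h; a higher number here means a weaker inhibitor, a lower number a stronger inhibitor:
- compound 1, `N#Cc1cnc(NCc2cnccc2C(F)(F)F)cc1NC[C@H]1CC[C@H](O)CC1`: 2000 nM
- compound 2, `CC1(C)C[C@H](Nc2cc(NCc3cnccc3C(F)(F)F)ncc2C#N)CC(C)(C)[C@H]1O`: 500 nM
- compound 3, `CC1(C)[C@H](O)C[C@@H]1Nc1nc(NCc2cnccc2C(F)(F)F)ncc1C#N`: 8500 nM

Compound 1 gives the second highest of the three numbers in this assay. Compound 2 sits nearest to it with a lower number, a gap beyond the scatter; compound 3 lies furthest from it with a higher number, again beyond the scatter. Within the data shown here, no pair of the three compounds differs in only one place, so none of these gaps can be read as a clean single step.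

Compound 4, `CC1(C)[C@@H](Nc2cc(NCc3cnccc3C(F)(F)F)ncc2C#N)C[C@H]1C(N)=O`, is not yet measured. Relative to compound 1 the change is 3-carbamoyl-2,2-dimethylcyclobutyl in place of (4-hydroxycyclohexyl)methyl on a nitrogen on an aromatic ring, with the shared core of compound 1 otherwise kept. The closest measured precedent is compound 2, where a substituted ring sits directly on the aromatic nitrogen and the number is lower than that of compound 1; compound 3 carries a small ring directly on that nitrogen too, but with a different core, and its number is higher. The step from compound 1 to compound 4 is therefore expected to be modest, likely towards a lower number, estimated as a 1.7-fold lower number from compound 1 to compound 4 (0.22 log units; within the scatter). For compound 4 the value in this assay is estimated at 1200 nM, with a range of 300 nM to 5000 nM.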

Compound 4, half-maximal inhibitory concentration: 4500 nM
Beside the measured number, compound 4's estimate is 3.8-fold (0.57 log units) below it, and the stated range covers the measured number.
By their numbers in this assay, from the lowest: compound 2; then compound 1; then compounds 4 and 3 (each within the scatter of the next).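

Among these compounds, this is the first step that can be read at a single place: in this assay, exchanging (4-hydroxycyclohexyl)methyl for 3-carbamoyl-2,2-dimethylcyclobutyl on the nitrogen on the aromatic ring gives a 2.3-fold higher number from compound 1 to compound 4 (0.35 log units; beyond the scatter). The position therefore accepts a six-membered ring on a one-carbon link or a four-membered ring bearing a carbamoyl group placed directly on the nitrogen, with a modest but real cost for this particular exchange, and the shared core is held constant across the step. No measurement shown accounts for the direction or size of this step.

The exchange alters ring size, the link to the nitrogen, the gem-dimethyl substitution and the polar group at once, so the compounds shown leave open which of these changes carries the higher number. Also open, on these data alone, is how the four-membered ring behaves with a different group in place of the carbamoyl, such as a carboxylic acid or a primary amine, on this same core.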